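The compounds below may be only part of what the source reports. "The series", "measured", "known", "first", "only" and "open" are said of these compounds alone.

Measured compounds in a functional assay on NCI-H460 cells (Homo sapiens) for antiproliferative activity, read by sulforhodamine B assay, with a stated time of 72 h; on this read-out lower numbers stand for stronger inhibition and higher numbers for weaker inhibition:
- compound 1, `C#CCNCCN(C)CCNc1ccnc2cc(Cl)ccc12`, gives 69000 nM
- compound 2, `CN(CCNCc1cn(-c2cccc(Cl)c2)nn1)CCNc1ccnc2cc(Cl)ccc12`, gives 17000 nM
- compound 3, `CN(CCNCc1cn(-c2ccc(Br)cc2)nn1)CCNc1ccnc2cc(Cl)ccc12`, gives 15000 nM

Compound 3 has the lowest of the three numbers. Its nearest neighbour is compound 2: the step of a 1.1-fold lower number from compound 2 to compound 3 (0.05 log units; within the scatter) lies within the scatter, so the two cannot be ranked. Within the data shown here, the value of compound 1 lies higher than that of compound 3, beyond the scatter; no single-point step connects these two, and only their two values are known.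

Compound 4, `CN(CCNCc1cn(Cc2nc3cc(Cl)ccc3[nH]2)nn1)CCNc1ccnc2cc(Cl)ccc12`, is not yet measured. It differs from compound 3 by (5-chloro-1H-benzimidazol-2-yl)methyl in place of 4-bromophenyl on an aromatic nitrogen. Among the measured compounds shown here, the only measured step at the same position is the exchange of one aryl group for another, a 1.1-fold lower number from compound 2 to compound 3 (0.05 log units; within the scatter), which did not move the number beyond the scatter. That step bears on compound 4 only in part: the entering group carries a methylene and a second ring with a hydrogen-bond donor and acceptor, a change of a different kind from the aryl-for-aryl swap. For the measured compounds named here, no measured pair shows what such a change does here. The working expectation is therefore a number near that of compound 3, with no step beyond the scatter in either direction, but with a wide range to allow for the unknown.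

Compound 4 is estimated at 12000 nM, between 4000 nM and 35000 nM, an expected step of a 1.3-fold lower number from compound 3 to compound 4 (0.10 log units; within the scatter).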

Compound 4, half-maximal inhibitory concentration: 59000 nM
Compound 4: the middle estimate sits 4.9-fold (0.69 log units) below what was measured, outside the stated range (above it).
By their numbers in this assay, from the lowest: compounds 3 and 2 (each within the scatter of the next); then compounds 4 and 1 (each within the scatter of the next).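

In this assay the aromatic nitrogen of the five-membered ring with 3 nitrogen turns out not to be indifferent to its substituent: (5-chloro-1H-benzimidazol-2-yl)methyl in place of 4-bromophenyl gives a 3.9-fold higher number from compound 3 to compound 4 (0.59 log units; beyond the scatter) and in place of 3-chlorophenyl gives a 3.5-fold higher number from compound 2 to compound 4 (0.54 log units; beyond the scatter) as the second reading of the same change. Among these compounds, the aryl-for-aryl exchange had stayed within the scatter, so this is the first change at this position seen to move the number beyond it, and both steps point towards weaker inhibition from two starting compounds that cannot themselves be ranked. No measurement at hand accounts for the loss.

The change brings in a methylene, a second ring and a hydrogen-bond donor and acceptor all at once, so the compounds shown do not separate the contribution of each. Going by these compounds, a benzyl group would test the methylene with a plain phenyl ring, and an unsubstituted (1H-benzimidazol-2-yl)methyl group would show what the chlorine contributes; how either would read here remains open.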